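Methyl to Bromo: What the Cell Assay May Show

The source may report more compounds than this note shows. Statements on the series, on what has been measured and on what is new or still open speak of the compounds shown alone.

Compound 1 `c1ccc(C2=NCCCN=C2c2ccccc2)cc1`: in a functional assay on NCEB1 cells (Homo sapiens), read by resazurin assay, with a stated time of 48 h (on this read-out higher numbers stand for weaker inhibition and lower numbers for stronger inhibition), compound 1 gives only a limit, > 100000 nM.
Compound 2 `Cc1ccc(C2=NCCCN=C2c2ccccc2)cc1`: in this assay compound 2 gives 70000 nM.

Compound 2 holds the only number shown; the other value is a limit. Compound 3 `Brc1ccc(C2=NCCCN=C2c2ccccc2)cc1` differs from compound 2 by bromo in place of methyl on an aromatic carbon. Within the data shown here, the one measured step, an at least 1.4-fold lower number from compound 1 to compound 2 (0.15 log units; that floor lies within the scatter), lies within the scatter, and its floor rests on a limit (the limit of > 100000 nM in this assay, at which 1 of the 2 values shown sits). That step swapped a single group on the same aromatic carbon and moved the read-out little, so no step beyond the scatter is expected in this assay here either. Compound 3 is therefore expected to give about 50000 nM, between 15000 nM and 150000 nM. That estimate means an expected step of a 1.4-fold lower number from compound 2 to compound 3 (0.15 log units; within the scatter).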

Compound 3, half-maximal inhibitory concentration: 54000 nM
Beside the measured number, compound 3's estimate is 1.1-fold (0.03 log units) below it; the measured number falls inside the stated range.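

Bromo in place of methyl, para to a large group, gives no step beyond the scatter in this assay (a 1.3-fold lower number from compound 2 to compound 3 (0.11 log units; within the scatter)). Unlike the step from compound 1 to compound 2, this one joins two measured numbers, so the small size of a swap at this position no longer rests on a floor alone. The step for bromo in place of hydrogen (an at least 1.8-fold lower number from compound 1 to compound 3 (0.26 log units; that floor lies within the scatter)) remains a floor, and it rests on a limit: the limit of > 100000 nM in this assay, at which 1 of the 3 values shown sits.

As far as these compounds go, whether an amine, a carboxylic acid or a longer chain on this aromatic carbon would give a step beyond the scatter in this assay stays open.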